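A few compounds are considered here, and "the series" means these few. Any claim that something is new, unique, unknown or untested is made for them only; others in the source may bear on it.

Working notes on the series. Two compounds have been run so far in a functional assay on the whole organism for inhibition, with Rattus norvegicus as the target, read by ELISA, with stated times of 30 min and 6 h, at a dose of 30 mg/kg by the oral route; on this read-out lower numbers stand for less inhibition and higher numbers for more inhibition at the one dose given (going by the name of the read-out). Compound 1 `N=c1sc(=S)[nH]c2c1cc(-c1ccc(Cl)cc1)n2-c1ccccc1` gives 2%. Compound 2 `CCn1c(=S)[nH]c2c(cc(-c3ccc(Cl)cc3)n2-c2ccccc2)c1=N` gives 61%, the higher of the two numbers, with compound 1 standing lower by a gap well beyond the usual scatter of this measurement. For the measured compounds named here, no pair among the measured compounds differs in only one place, so no single-point step is available to lean on.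

Compound 3 `CCn1c(=S)[nH]c2c(cc(-c3ccc(Br)cc3)n2-c2ccccc2)c1=N` has not been measured. It is built on compound 2 and differs from it in one spot: bromo in place of chloro on an aromatic carbon. Going by the values given here, nothing in the numbers so far speaks to a halogen swap of this kind; the only comparison to hand, compound 1 against compound 2, involves several changes at once and cannot be read as a guide here. The step in this assay from compound 2 to compound 3 is therefore expected to be small, a number 3 percentage points lower from compound 2 to compound 3 (within the scatter), within the scatter and without a clear direction. Compound 3 is estimated at 58%, with a range from 35% to 78%.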

Compound 3, a percentage reported as inhibition, in the whole organism at one dose (the size of the read-out at that dose, not a potency): 80%
The estimate for compound 3 lay 22 percentage points below the measured number, and the stated range ends below it.
By their numbers in this assay, from the lowest: compound 1; then compound 2; then compound 3.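

In this assay, the halogen on the 4-chlorophenyl group proves to matter: bromo in place of chloro gives a number 19 percentage points higher from compound 2 to compound 3 (beyond the scatter), the first single-point step available in the series. The change is confined to one heavy atom on an aromatic carbon, para to a large group, with no ring, hydrogen-bond donor, hydrogen-bond acceptor or net charge entering or leaving, so even this small edit at this position can move the read-out beyond the scatter at the one dose given. Nothing measured on these compounds bears on why the step occurs.

With only chloro and bromo shown at this position, it remains open whether the trend from chloro to bromo extends to iodo, and how fluoro, a methoxy group or an amine would read there. Also open, as far as these compounds go, is whether the same swap gives a similar step on other versions of the shared core, such as one carrying a propyl chain in place of the ethyl group of compound 2 and compound 3.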